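Compound 2 Gains a Cyclopropyl Group

This account rests on a few compounds, and the source may have more. Where it says the series, first, only, none or still open, it means among the compounds named here.

Of the compounds shown here, two have so far been measured in a physicochemical assay for lipophilicity, using the shake flask method; a lower number here means a more polar compound, a higher number a more lipophilic compound. Compound 1 (`C[C@H](Oc1ccc2nc(OCCN)c(CCC(=O)O)c(C3CC3)c2c1)c1c(Cl)ccc(F)c1Cl`) gives 3.8, while compound 2 (`C[C@H](Oc1ccc2ncc(/C=C/C(=O)O)cc2c1)c1c(Cl)ccc(F)c1Cl`) gives 2.5. That is the lower of the two numbers, and the gap between them lies beyond the scatter of repeat measurements.

Compound 3 (`C[C@H](Oc1ccc2ncc(/C=C/C(=O)O)c(C3CC3)c2c1)c1c(Cl)ccc(F)c1Cl`) has not yet been measured. It differs from compound 2 in one place: cyclopropyl in place of hydrogen on an aromatic carbon, which means cyclopropyl in place of hydrogen on an aromatic carbon. Among the compounds with values here, no measured pair shows this single change on its own. Compound 1 also carries a cyclopropyl group, but it differs from compound 2 elsewhere too, so compound 1, at 3.8, is only a loose guide, pointing upward. A moderate rise in this assay is expected, a number 0.70 log units higher from compound 2 to compound 3 (beyond the scatter). Compound 3 is estimated at 3.2, with an expected range of 2.8 to 3.6.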

Compound 3, distribution coefficient: 4.1
Estimate against measurement, compound 3: 0.90 log units below; measured number outside the range, above it.
By their numbers in this assay, from the lowest: compound 2; then compounds 1 and 3 (each within the scatter of the next).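

In this assay the exchange of hydrogen for cyclopropyl on this aromatic carbon, ortho to a 2-carboxyethenyl group and opposite the ring nitrogen, gives a number 1.60 log units higher from compound 2 to compound 3 (beyond the scatter) and counts as a large step. Within the data shown here, this is the first pair that shows this single change on its own, so its size at this position can be read directly rather than judged loosely from compound 1, which differs in more than one place. No measurement at hand accounts for the size of this step.

The compounds shown leave open whether a methyl or an isopropyl group at this position would give a step of similar size. They also leave open whether cyclopropyl would give the same step if an amide stood in place of the carboxylic acid.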